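A few compounds are considered here, and "the series" means these few. Any claim that something is new, unique, unknown or untested is made for them only; others in the source may bear on it.

Among the compounds with values here, in a functional assay on MDA-MB-231 cells (Homo sapiens) for inhibition, read by MTT assay, with a stated time of 5 days (on this read-out lower numbers stand for stronger inhibition and higher numbers for weaker inhibition), compound 1 `Cc1cc(Nc2nc(NCc3ccc(Cl)cc3)nc3c2cnn3C2CCOCC2)n[nH]1` gives 9420 nM and compound 2 `Cc1cc(Nc2nc(NCc3ccc(F)cc3F)nc3c2cnn3C2CCOCC2)n[nH]1` gives 2880 nM, the lower of the only two numbers measured so far. Compound 3 `Cc1cc(Nc2nc(NCc3ccc(F)cc3F)nc3c2cnn3C2CCCCC2)n[nH]1` keeps everything in compound 2 except one group, with cyclohexyl in place of oxan-4-yl on an aromatic nitrogen. The ring stays six-membered and non-aromatic, but it is now of carbon only.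

Within the data shown here, only one measured step is available, a 3.3-fold lower number from compound 1 to compound 2 (0.51 log units; beyond the scatter). That step changed the aryl group on a saturated chain carbon, not the group on the aromatic nitrogen, so it bears on the new change only indirectly. It shows that one substitution on these molecules can shift the number modestly, but it gives no direction for this swap. Among the measured compounds shown here, no measured pair varies the group on the aromatic nitrogen, so in this assay the expectation is no change beyond the scatter. The estimated result is a 1.2-fold lower number from compound 2 to compound 3 (0.06 log units; within the scatter). For compound 3 the expected value is 2500 nM, with an estimated range from 800 nM to 7500 nM.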

Compound 3, half-maximal inhibitory concentration: 2960 nM
Estimate against measurement, compound 3: 1.2-fold (0.07 log units) below; measured number inside the range.
By their numbers in this assay, from the lowest: compounds 2 and 3 (each within the scatter of the next); then compound 1.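

Within the data shown here, the swap on the aromatic nitrogen is the first measured change at this position, and in this assay it gives a 1.0-fold higher number from compound 2 to compound 3 (0.01 log units; within the scatter). Oxan-4-yl carries one ring oxygen and one hydrogen-bond acceptor, while cyclohexyl is of carbon only and has no acceptor, yet this read-out does not separate the two groups in this pair of compounds. Nothing given here explains why the two groups read alike.

As far as these compounds go, both groups are six-membered non-aromatic rings with the same count of heavy atoms, so it remains open whether this position would respond to a different kind of group, such as a small isopropyl group, a flat phenyl ring or a piperidine ring with its amine. Among these compounds, it is also open whether the same swap would read alike with the 4-chlorophenyl group of compound 1, as this single step was seen only with the 2,4-difluorophenyl group in place.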